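Trading the Acid of Compound 1 for a Nitrile

The source may hold more compounds than are shown below. What is called first, only, known or untested is meant among the compounds shown, and "the series" means these compounds.

Compound 1 `O=C(O)CCCOc1cc(-c2ccccc2)cc(-c2ccccc2)n1` is one of three related compounds tested in an assay on cell membranes from spleen (Cavia porcellus) for binding affinity to leukotriene B4 receptor 1 (Homo sapiens); on this read-out higher numbers stand for weaker inhibition and lower numbers for stronger inhibition. In that test compound 1 gives 300 nM, and compound 2 `Cc1ccc(-c2cc(-c3ccccc3)cc(OCCCCCC(=O)O)n2)cc1` gives 300 nM; these two numbers are level within the scatter and together are the highest of the three. Compound 3 `CC(C)(CCCCOc1cc(-c2ccc(N)cc2)cc(-c2ccccc2)n1)C(=O)O` gives a much lower number, 6.6 nM. Compound 4 `N#CCCCCCOc1cc(-c2ccccc2)cc(-c2ccccc2)n1` has not yet been measured. It differs from compound 1 by a single change: 2-cyanoethyl in place of carboxy on a saturated chain carbon, three bonds along the chain from an oxygen on an aromatic ring. The acid group that every measured compound carries is therefore gone. Within the data shown here, no measured pair shows this change, so the step that is expected, a 5.0-fold higher number from compound 1 to compound 4 (0.70 log units; beyond the scatter), is a cautious guess toward a higher number. Compound 4 is expected to give about 1500 nM, somewhere between 400 nM and 6000 nM.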

Compound 4, half-maximal inhibitory concentration: 700 nM
Beside the measured number, compound 4's estimate is 2.1-fold (0.33 log units) above it; the range from low to high includes it.
By their numbers in this assay, from the lowest: compound 3; then compounds 1 and 2 (each within the scatter of the next); then compound 4.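

In this assay putting 2-cyanoethyl in place of carboxy at this position gives a 2.3-fold higher number from compound 1 to compound 4 (0.37 log units; beyond the scatter) and so only a modest weakening. Among these compounds, all the earlier compounds carry the acid, so they could not show that a compound without it still gives a number in the same broad range. At this position, the carboxy group is therefore not needed for inhibition on this read-out.

On these data alone, whether a primary amide or an amine at the chain end would do better remains open, and the swap changes both the end group and the chain length. No data here explain the size of this step.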